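The compounds below may be only part of what the source reports. "The series", "measured", "known", "first", "only" and "open" are said of these compounds alone.

Compound 2 `CCN(CC)c1ccc(/C=C2/SC(N(C)c3ccccc3)=NC2=O)cc1` has been examined in an ADME assay on cells (Homo sapiens) for cytotoxicity, read by sulforhodamine B assay, with a stated time of 48 h; a higher number here means that more compound is needed for the effect, a lower number that less compound is needed. In this assay compound 2 gives > 100000 nM, which is a limit of the assay rather than a number. Compound 1 `CN(C)c1ccc(/C=C2/SC(N(C)c3ccccc3)=NC2=O)cc1` likewise gives > 100000 nM, again a limit. The step that the two limits leave unreadable from compound 1 to compound 2 therefore cannot be read, and both values sit at the limit of > 100000 nM in this assay, at which 2 of the 2 values shown sit. Compound 3 `CN(C1=NC(=O)/C(=C\c2ccc(N3CCNCC3)cc2)S1)c1ccccc1` differs from compound 2 by piperazin-1-yl in place of diethylamino on an aromatic carbon. No readable measured step bears on this change, so no direction beyond the scatter is expected in this assay, and the step from compound 2 to compound 3 is expected to be a number no higher from compound 2 to compound 3 (the limit leaves the size open). Compound 3 is estimated at 100000 nM, within 30000 nM to 300000 nM.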

Compound 3, half-maximal effective concentration: > 100000 nM
Compound 3: no number, only a limit; the forecaster's own chance of this, stated with the estimate: 70%; the middle value lies on the limit itself.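

In this assay compound 3 gives > 100000 nM as a limit, not a number. For the compounds shown here, no step among compound 1, compound 2 and compound 3 can be read: the limit of > 100000 nM in this assay, at which 3 of the 3 values shown sit. Going by these compounds, how much of each compound the effect requires, and so whether dimethylamino, diethylamino or piperazin-1-yl makes any difference, stays open.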